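Removing the Nitro Group from Compound 2

The source may hold more compounds than are shown below. What is called first, only, known or untested is meant among the compounds shown, and "the series" means these compounds.

- compound 1 `COc1cccc(/C=C/C(=O)c2ccc(OC)c3c2OC(C)(C)C=C3)c1`: > 10000 nM
- compound 2 `COc1ccc(C(=O)/C=C/c2ccc([N+](=O)[O-])cc2)c2c1C=CC(C)(C)O2`: 7770 nM

For the measured compounds named here, in a functional assay on K562 cells (Homo sapiens) for antiproliferative activity, read by MTT assay, with a stated time of 24 h (on this read-out lower numbers stand for stronger inhibition and higher numbers for weaker inhibition), compound 2 gives 7770 nM, the only true number so far. Compound 1 gives only a limit of the assay, > 10000 nM.

Compound 3 `COc1ccc(C(=O)/C=C/c2ccccc2)c2c1C=CC(C)(C)O2` differs from compound 2 by one change, hydrogen in place of nitro on an aromatic carbon, para to a large group. Put another way, 4-nitrophenyl becomes phenyl.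

Going by the values given here, one measured step bears on this, as it also changes the group on the same chain: an at least 1.2-fold lower number from compound 1 to compound 2 (0.10 log units; that floor lies within the scatter). Its floor lies within the scatter, so it gives no firm size or direction. No step beyond the scatter is therefore expected in this assay, and the estimated change is a 1.2-fold higher number from compound 2 to compound 3 (0.06 log units; within the scatter). Compound 3 is expected at 9000 nM, with an estimated range of 4000 nM to 20000 nM.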

Compound 3, half-maximal inhibitory concentration: > 10000 nM
Compound 3 gave a limit, no number; the forecaster's own chance of this, stated with the estimate: 45%; middle value at least 1.1-fold (0.04 log units) from the limit.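

In this assay, replacing the nitro group with hydrogen, para to a large group, gives an at least 1.2-fold higher number from compound 2 to compound 3 (0.10 log units; that floor lies within the scatter). For the compounds shown here, the 4-nitrophenyl of compound 2 thus remains the only group here with a number rather than a limit, but the floor of this step lies within the scatter, so it does not show that the nitro group matters in this assay. Compound 1 and compound 3 both give only a limit, so the step between them cannot be read, and the set now rests largely on one boundary: the limit of > 10000 nM in this assay, at which 2 of the 3 values shown sit.

From the compounds shown here alone, it remains open whether another group at this place, such as an amine or a carboxylic acid, would give a number clearly lower than that of compound 2, 7770 nM. Going by these compounds, how far compound 3 lies past its limit also remains unknown, which leaves the full size of the change from nitro to hydrogen open.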